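Vinyl for methylsulfanyl on the shared core: cytotoxicity outlook

The source may report more compounds than this note shows. Statements on the series, on what has been measured and on what is new or still open speak of the compounds shown alone.

Measured compounds:
compound 1, `O=C(Nc1ccc(Cl)cc1)C1CCCN(C(=O)c2cccc(-c3nccs3)c2)C1`: 32%
compound 2, `Cc1nc(-c2cccc(C(=O)N3CCCC(C(=O)Nc4ccc(Cl)cc4)C3)c2)no1`: 0%
compound 3, `CSc1cccc(C(=O)N2CCCC(C(=O)Nc3ccc(Cl)cc3)C2)c1`: 0%

In an ADME assay on PC-3 cells (Homo sapiens) for cytotoxicity, read by WST assay, tested at 100 uM (a higher number here means more inhibition at the concentration tested (going by the name of the read-out), a lower number less inhibition), compound 1 gives 32%, and compound 2 gives 0%, while compound 3 gives 0%. Compound 3 is level with compound 2 at the digits shown, and the two of them together sit lowest of the three; the only number that differs beyond the scatter is that of compound 1, which lies a number 32 percentage points lower from compound 1 to compound 3 (beyond the scatter). The step of no change at the digits printed from compound 2 to compound 3 (within the scatter) shows that swapping one small aromatic substituent for another left the read-out unmoved.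

Compound 4, `C=Cc1cccc(C(=O)N2CCCC(C(=O)Nc3ccc(Cl)cc3)C2)c1`, is not yet measured. It differs from compound 3 by vinyl in place of methylsulfanyl on an aromatic carbon. Both steps onto compound 3 bear on this: a number 32 percentage points lower from compound 1 to compound 3 (beyond the scatter) and no change at the digits printed from compound 2 to compound 3 (within the scatter). The first is large, but the second, which exchanges one small substituent at the same aromatic carbon for another, is within the scatter. Compound 4 again exchanges one small substituent for another at that carbon, so no step beyond the scatter is expected: a number 5 percentage points higher from compound 3 to compound 4 (within the scatter). Compound 4 is therefore estimated at 5%, with a range from 0% to 20%.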

Compound 4, a percentage reported as inhibition, at one concentration (the size of the read-out at that concentration, not a potency): 0%
Estimate against measurement, compound 4: 5 percentage points above, within the range that was stated.
By their numbers in this assay, from the lowest: compounds 2, 3 and 4 (each within the scatter of the next); then compound 1.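

In this assay, the exchange at this aromatic carbon gives no change at the digits printed from compound 3 to compound 4 (within the scatter), so removing methylsulfanyl with its sulfur and its hydrogen-bond acceptor in favour of vinyl, which has neither, leaves the read-out where it was. Vinyl also matches the ring-bearing 5-methyl-1,2,4-oxadiazol-3-yl, with no change at the digits printed from compound 2 to compound 4 (within the scatter), while the 1,3-thiazol-2-yl group remains the only one of the four substituents that stands apart, with a number 32 percentage points lower from compound 1 to compound 4 (beyond the scatter), so compound 1 is now set against three level compounds rather than two. No measured information on these compounds accounts for that separation.

On these data alone, whether the higher number belongs to the 1,3-thiazol-2-yl group alone, or would also appear with another aromatic ring at this carbon, such as phenyl or pyridine, remains open. It is equally unsettled whether an amine or a carboxylic acid at this position would stay level with compounds 2, 3 and 4 or move towards compound 1 in this assay.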